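The source may report more compounds than this note shows. Statements on the series, on what has been measured and on what is new or still open speak of the compounds shown alone.

Of the compounds shown here, three built on one shared core have been tested in a functional assay on A549 cells (Homo sapiens) for antiproliferative activity, read by MTT assay, with a stated time of 48 h; a lower number here means a stronger inhibitor, a higher number a weaker inhibitor. Compound 1 `CO[C@]1(C)/C=C/C(=O)/C(CO)=C\C[C@](C)(CCC=C(C)C)/C=C/[C@H]1OC(=O)C=C(C)C` gives 14400 nM in this assay. Compound 2 `CC(C)=CCC[C@]1(C)/C=C/[C@@H](OC(=O)C=C(C)C)[C@](C)(O)/C=C/C(=O)/C(CCl)=C\C1` gives 150 nM, the lowest of the three numbers. Compound 3 `CC(C)=CCC[C@]1(C)/C=C/[C@@H](OC(=O)C=C(C)C)[C@](C)(O)/C=C/C(O)/C(C=O)=C\C1` gives 570 nM, a gap from compound 2 that lies beyond the scatter, while compound 1 stands furthest from compound 2. Compound 4 `CCN(CC)C(=O)/C1=C/C[C@](C)(CCC=C(C)C)/C=C/[C@@H](OC(=O)C=C(C)C)[C@](C)(O)/C=C/C1=O` has not yet been measured. It differs from compound 2 at a single place: diethylcarbamoyl in place of chloromethyl on a double-bonded ring carbon. Among the compounds with values here, no step between measured compounds bears on this exchange. Compound 4 is expected to be the weaker inhibitor, by a step of a 17-fold higher number from compound 2 to compound 4 (1.22 log units; beyond the scatter). That expectation rests on compound 1, which gives 14400 nM, and compound 3, which gives 570 nM, both without chloromethyl. The estimate for compound 4 is 2500 nM, in the range 500 nM to 12000 nM.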

Compound 4, half-maximal inhibitory concentration: 11300 nM
Compound 4: middle estimate off by 4.5-fold (0.66 log units), on the low side, and the stated range covers the measured number.
By their numbers in this assay, from the lowest: compound 2; then compound 3; then compounds 4 and 1 (each within the scatter of the next).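

In this assay, within the data shown here, the exchange of chloromethyl for diethylcarbamoyl on the double-bonded ring carbon gives a 75-fold higher number from compound 2 to compound 4 (1.88 log units; beyond the scatter), the first direct reading at this position. It shows that the number is highly sensitive to this single exchange, with the weaker inhibitor carrying the diethylcarbamoyl group. Nothing available explains this step. The compounds shown leave open whether the loss follows the amide carbonyl or the two ethyl groups. They also leave open whether bromomethyl, aminomethyl or an unsubstituted carboxamide here would stay close to compound 2.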